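Replacing the second methoxy with nitro

This account rests on a few compounds, and the source may have more. Where it says the series, first, only, none or still open, it means among the compounds named here.

Measured in an ADME assay on MDBK cells (Bos taurus) for cytotoxicity, read by MTT assay, with a stated time of 96 h; a lower number here means that less compound is tolerated, a higher number that more compound is tolerated:
- Compound 1 `COc1ccc(-c2nc3cc(C(F)(F)F)ccc3[nH]2)c(OC)c1`: > 100000 nM, a limit and not a number
- Compound 2 `COc1cc(-c2nc3cc(C(F)(F)F)ccc3[nH]2)cc(OC)c1OC`: 18000 nM
- Compound 3 `COc1ccc(-c2nc3cc(C(F)(F)F)ccc3[nH]2)c([N+](=O)[O-])c1`: 55000 nM

Compound 3 at 55000 nM holds the higher of the two true numbers, with compound 2 at 18000 nM. Compound 4 `O=[N+]([O-])c1ccc(-c2nc3cc(C(F)(F)F)ccc3[nH]2)c([N+](=O)[O-])c1` carries nitro in place of methoxy on an aromatic carbon, meta to a nitro group and para to a large group (nitro in place of methoxy on an aromatic carbon). One measured step made the same exchange: an at least 1.8-fold lower number from compound 1 to compound 3 (0.25 log units; that floor lies within the scatter). That single step is only a floor, so the same direction is expected here, with a modest size. The expected change is a 2.0-fold lower number from compound 3 to compound 4 (0.31 log units; beyond the scatter). For compound 4 the estimated value is 27000 nM, with an expected range of 9000 nM to 80000 nM.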

Compound 4, half-maximal cytotoxic concentration: 16000 nM
The estimate for compound 4 lay 1.7-fold (0.23 log units) above the measured number; the measured number falls inside the stated range.
By their numbers in this assay, from the lowest: compounds 4 and 2 (each within the scatter of the next); then compound 3. At a limit, above all of these: compound 1.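

In this assay, nitro in place of methoxy at this position, meta to a nitro group and para to a large group, gives a 3.4-fold lower number from compound 3 to compound 4 (0.54 log units; beyond the scatter), and this step joins two true numbers. The earlier exchange ran in the same direction at the other methoxy, but it gave only a floor, because compound 1 stands at a limit: the limit of > 100000 nM in this assay, at which 1 of the 4 values shown sits.

Only this one replacement at this position can be read, so no trend across substituents follows from it. Going by these compounds, how an amine or a carboxylic acid there would compare remains open.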